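A Five-Membered Ring Swap and Its Expected Dose

The source may report more compounds than this note shows. Statements on the series, on what has been measured and on what is new or still open speak of the compounds shown alone.

Compound 1 `O=C(O)c1cc(-c2cncs2)ccc1O` sits only at a limit in a functional assay on the whole organism for inhibition, with Rattus norvegicus as the target, read by paw edema; on this read-out lower numbers stand for an effect already at smaller amounts and higher numbers for an effect only at larger amounts of compound: compound 1 gives > 200 mg/kg, which is a limit of the assay rather than a number (the limit of > 200 mg/kg in this assay, at which 1 of the 3 values shown sits). Two measured partners replace the same ring. Compound 2 `O=C(O)c1cc(-n2ccnc2)ccc1O` gives 75 mg/kg, and compound 3 `O=C(O)c1cc(-n2ccnn2)ccc1O` gives 150 mg/kg. The steps of an at least 2.6-fold lower number from compound 1 to compound 2 (0.42 log units; beyond the scatter) and an at least 1.3-fold lower number from compound 1 to compound 3 (0.12 log units; that floor lies within the scatter) both lower the number, the second only with a floor inside the scatter. Between the two partners, a 2.0-fold higher number from compound 2 to compound 3 (0.30 log units; within the scatter). Compound 4 `O=C(O)c1cc(-c2ncc[nH]2)ccc1O` follows the same route: 1H-imidazol-2-yl in place of 1,3-thiazol-5-yl on an aromatic carbon. With a lowering seen in both related steps, a modest lowering is expected for compound 4, an at least 1.6-fold lower number from compound 1 to compound 4 (0.22 log units; that floor lies within the scatter), while another limit remains possible. Compound 4 is therefore estimated at 120 mg/kg, between 50 mg/kg and 300 mg/kg.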

Compound 4, dose for half-maximal effect: 200 mg/kg
Compound 4: the middle estimate sits 1.7-fold (0.22 log units) below what was measured, within the range that was stated.
By their numbers in this assay, from the lowest: compounds 2, 3 and 4 (each within the scatter of the next, the first and the last beyond it).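

The swap of the ring gives a number no higher from compound 1 to compound 4 (the limit leaves the size open). The size of that step cannot be read, because compound 1 stands at a limit: the limit of > 200 mg/kg in this assay, at which 1 of the 4 values shown sits. Moving the attachment of the imidazole ring from 1H-imidazol-1-yl to 1H-imidazol-2-yl gives a 2.7-fold higher number from compound 2 to compound 4 (0.43 log units; beyond the scatter), so in this assay the point of attachment alone can shift the dose. Against the triazole ring the change is a 1.3-fold higher number from compound 3 to compound 4 (0.12 log units; within the scatter), which leaves compound 3 and compound 4 indistinguishable. Still open, going by these compounds, is how an amine or a longer alkyl chain in place of the five-membered ring, para to the hydroxy group, would compare.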